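Phenylsulfonyl for benzoyl on an indolyl acrylonitrile scaffold

This account rests on a few compounds, and the source may have more. Where it says the series, first, only, none or still open, it means among the compounds named here.

Measured compounds:
Compound 1, `N#C/C(=C\c1c(-c2ccccc2)[nH]c2ccccc12)C(=O)c1ccccc1`, 4500 nM
Compound 2, `COc1ccc(-c2[nH]c3ccc(OC)cc3c2/C=C(\C#N)S(=O)(=O)c2ccccc2)cc1`, 687 nM
Compound 3, `COc1ccc2[nH]c(-c3ccccc3)c(C=C(C#N)C#N)c2c1`, 3600 nM

Of the compounds shown here, three have been tested in a functional assay on NCI-H460 cells (Homo sapiens) for inhibition, read by sulforhodamine B assay, with a stated time of 48 h; on this read-out lower numbers stand for stronger inhibition of growth and higher numbers for weaker inhibition of growth. Compound 1 stands at the highest number of the three. Its nearest neighbour is compound 3, whose value lies within the scatter of compound 1, so the two cannot be told apart. Compound 2 is the furthest away, with a number well below compound 1 and beyond the scatter; compound 2 carries a phenylsulfonyl group and two methoxy groups, so the two values alone do not tell which part of the structure accounts for the gap.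

Compound 4, `N#C/C(=C\c1c(-c2ccccc2)[nH]c2ccccc12)S(=O)(=O)c1ccccc1`, has not yet been measured in this assay. It differs from compound 1 in one place: phenylsulfonyl in place of benzoyl on a double-bonded chain carbon bound to a double-bonded chain carbon and a triple-bonded carbon. Within the data shown here, no step between measured compounds isolates this change, and compound 2 differs from compound 4 in more than one place. Still, the lower number of compound 2 at 687 nM is the only hint available, and it points toward a lower number for compound 4. A moderate step is expected from compound 1 to compound 4 in this assay, a 3.0-fold lower number from compound 1 to compound 4 (0.48 log units; beyond the scatter), toward stronger inhibition. Compound 4 is therefore estimated at 1500 nM, within a range from 500 nM to 5000 nM.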

Compound 4, concentration for 50% growth inhibition: 2700 nM
For compound 4 the middle estimate is 1.8-fold (0.26 log units) below the measured one, and the stated range covers the measured number.
By their numbers in this assay, from the lowest: compound 2; then compounds 4, 3 and 1 (each within the scatter of the next).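

In this assay, among these compounds, phenylsulfonyl in place of benzoyl on a double-bonded chain carbon bound to a double-bonded chain carbon and a triple-bonded carbon gives a 1.7-fold lower number from compound 1 to compound 4 (0.22 log units; within the scatter) and this is the first reading of that position with nothing else in the structure differing. On the core of compound 1 the two groups therefore cannot be told apart on this read-out, even though the entering group brings a sulfur atom in place of the carbonyl carbon. Nothing shown here explains why the two groups read alike.

Compound 2 differs from compound 4 in more than one place, so the compounds shown cannot say whether its two methoxy groups, its phenylsulfonyl group on that altered core, or both together go with its lower number. Also open, from the compounds shown here alone, is how far this position accepts groups of another kind, such as a carboxylic acid, a primary amide or a short alkyl ester, and whether the equivalence of benzoyl and phenylsulfonyl holds on a core carrying methoxy groups.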